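Phenyl for Methyl on the Imidate Carbon

The source may report more compounds than this note shows. Statements on the series, on what has been measured and on what is new or still open speak of the compounds shown alone.

Among the measured compounds shown here, in an ADME assay on the whole organism (plasma) for pharmacokinetics, with Homo sapiens as the target, in phosphate buffer, at pH 7.4 (on this read-out higher numbers stand for a longer-lived compound and lower numbers for a shorter-lived compound), compound 2 `CCO/C(C)=N\S(=O)(=O)c1ccc(C)cc1` gives 0.107 h, the only number in this small set. In this assay compound 1 `CCO/C=N\S(=O)(=O)c1ccc(C)cc1` gives < 0.0167 h, which is a limit of the assay and not a number. Compound 3 `CCO/C(=N\S(=O)(=O)c1ccc(C)cc1)c1ccccc1` is not yet measured; it differs from compound 2 by phenyl in place of methyl on a carbon with a double bond to nitrogen. For the measured compounds named here, no step between measured compounds is known, so the expectation rests on the change alone. Compound 3 is expected to be longer-lived, with a step of a 4.7-fold higher number from compound 2 to compound 3 (0.67 log units; beyond the scatter) beyond the scatter. Compound 3 is estimated at 0.5 h, between 0.1 h and 3 h.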

Compound 3, half-life: 0.333 h
Beside the measured number, compound 3's estimate is 1.5-fold (0.18 log units) above it, within the range that was stated.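

Phenyl in place of methyl on a carbon with a double bond to nitrogen gives a 3.1-fold higher number from compound 2 to compound 3 (0.49 log units; beyond the scatter) in this assay, which makes this the first change at this position with a size that can be read. It also shows that a six-membered aromatic ring at this carbon goes with a longer-lived compound than methyl. Any step from compound 1 cannot be read, as its value is a limit of the assay and not a number: the limit of < 0.0167 h in this assay, at which 1 of the 3 values shown sits.

The compounds shown leave open whether the ring's aromatic character matters, which a cyclohexyl group on the same carbon would test. They also leave open how an amine there would compare.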